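Swapping the Anilino Arm for a Benzyl Methyl Amine

The compounds below may be only part of what the source reports. "The series", "measured", "known", "first", "only" and "open" are said of these compounds alone.

The shared core, seen in compound 1 `COc1ccccc1Nc1cc(C)nc(SCc2nc3ccccc3[nH]2)n1`, carries an amine-bearing arm that is varied across this small series. In a functional assay on MCF7 cells (Homo sapiens) for cytotoxicity, read by MTT assay, with a stated time of 72 h (on this read-out lower numbers stand for stronger inhibition and higher numbers for weaker inhibition), compound 1 gives > 100000 nM, which is a limit of the assay rather than a number. Compound 2 `Cc1cc(Nc2cccc(C(F)(F)F)c2)nc(SCc2nc3ccccc3[nH]2)n1` gives > 100000 nM in this assay, again a limit. Compound 3 `Cc1cc(NC(C)C)nc(SCc2nc3ccccc3[nH]2)n1` gives > 100000 nM, also a limit. The step that the two limits leave unreadable from compound 1 to compound 3 therefore cannot be read, and the whole picture is simply (the limit of > 100000 nM in this assay, at which 3 of the 3 values shown sit). Compound 4 `Cc1cc(N(C)Cc2ccccc2)nc(SCc2nc3ccccc3[nH]2)n1` differs from compound 1 by benzyl(methyl)amino in place of (2-methoxyphenyl)amino on an aromatic carbon. Among the measured compounds shown here, no measured step shows a readable size, so nothing beyond the scatter is expected, and compound 4 is expected to sit near 100000 nM, between 30000 nM and 300000 nM. The step of a number no higher from compound 1 to compound 4 (the limit leaves the size open) is expected to be flat.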

Compound 4, half-maximal inhibitory concentration: > 100000 nM
Compound 4 was reported as a limit (the forecaster's own chance of this, stated with the estimate: 80%); the middle value sits exactly at the limit.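

The steps from compound 1 and from compound 3 to compound 4 cannot be read, as all four results are the same assay limit: the limit of > 100000 nM in this assay, at which 4 of the 4 values shown sit. The compounds shown leave open whether any amine-bearing arm on the shared core gives a true number rather than a limit.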